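Replacing carboxy with (diethylamino)methyl

A few compounds are considered here, and "the series" means these few. Any claim that something is new, unique, unknown or untested is made for them only; others in the source may bear on it.

Measured in a functional assay on MCF7 cells (Homo sapiens) for antiproliferative activity, read by MTT assay, with a stated time of 48 h; on this read-out lower numbers stand for stronger inhibition and higher numbers for weaker inhibition:
- compound 1 `CC(C)=CCC[C@]1(C)/C=C/[C@@H](OC(=O)C=C(C)C)[C@](C)(O)/C=C/C(=O)/C(CF)=C\C1`: 240 nM
- compound 2 `CC(=O)OC/C1=C/C[C@](C)(CCC=C(C)C)/C=C/[C@@H](OC(=O)C=C(C)C)[C@](C)(OC(C)=O)/C=C/C1=O`: 3990 nM
- compound 3 `CC(C)=CCC[C@]1(C)/C=C/[C@@H](OC(=O)C=C(C)C)[C@](C)(O)/C=C/C(=O)/C(C(=O)O)=C\C1`: 16100 nM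

Compound 3 has the highest number of the three. Compound 2 lies nearest to it and compound 1 furthest away. The next change leads to compound 4 `CCN(CC)C/C1=C/C[C@](C)(CCC=C(C)C)/C=C/[C@@H](OC(=O)C=C(C)C)[C@](C)(O)/C=C/C1=O`, with (diethylamino)methyl in place of carboxy on a double-bonded ring carbon.

Going by the values given here, one measured step bears directly on this ring carbon: a 67-fold higher number from compound 1 to compound 3 (1.83 log units; beyond the scatter). It is large and shows that a change at this carbon alone can move the number well beyond the scatter. Compound 2 is a looser guide, since it differs from compound 3 in more than one place. The expectation of a lower number rests on compound 1 at 240 nM and compound 2 at 3990 nM, which both lack carboxy at this carbon. Among the compounds with values here, no measured compound carries (diethylamino)methyl, so the size of the step remains uncertain, and a result as low as that of compound 1 is not assumed.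

The expected change is an 8.9-fold lower number from compound 3 to compound 4 (0.95 log units; beyond the scatter), a moderate to large step towards stronger inhibition. In this assay, compound 4 is estimated at 1800 nM, within an expected range of 400 nM to 8000 nM.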

Compound 4, half-maximal inhibitory concentration: 130 nM
Estimate against measurement, compound 4: 14-fold (1.14 log units) above, outside the stated range (below it).
By their numbers in this assay, from the lowest: compounds 4 and 1 (each within the scatter of the next); then compound 2; then compound 3.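

In this assay, going by these compounds alone, the step with (diethylamino)methyl in place of carboxy is a 120-fold lower number from compound 3 to compound 4 (2.09 log units; beyond the scatter) and shows that this double-bonded ring carbon can recover the large loss seen earlier with carboxy, while fluoromethyl is not the only group that gives a low number here. The comparison with the fluoromethyl compound gives a 1.8-fold lower number from compound 1 to compound 4 (0.27 log units; within the scatter) so that, among these compounds, fluoromethyl and (diethylamino)methyl are not separated in this assay, although the groups differ in size and in their atoms. Compound 3 is therefore the outlier among the three compounds that differ only at this carbon, and nothing available explains why its carboxy group stands apart from the other two groups.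

The compounds shown leave open whether a smaller amine such as (dimethylamino)methyl, a ring amine such as morpholinomethyl or a neutral hydroxymethyl group at this carbon would stay with compound 1 and compound 4 or move towards compound 3. They also leave open how acetoxymethyl alone behaves here, since compound 2 carries a second change on the hydroxy group.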